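This account rests on a few compounds, and the source may have more. Where it says the series, first, only, none or still open, it means among the compounds named here.

Measured in an assay on isolated protein for inhibition of Polyunsaturated fatty acid 5-lipoxygenase (Homo sapiens), read by HPLC, with a stated time of 10 min; a higher number here means a weaker inhibitor, a lower number a stronger inhibitor:
Compound 1, `Cc1cc(NC(=O)Nc2ccccc2)ccc1OCc1nc2ccccc2s1`: 2070 nM
Compound 2, `Cc1cc(NC(=O)Nc2ccc(Cl)cc2)ccc1OCc1nc2ccccc2s1`: > 10000 nM, which is a limit of the assay and not a number.
Compound 3, `Cc1cc(NC(=O)Nc2cc(Cl)cc(Cl)c2)ccc1OCc1nc2ccccc2s1`: 720 nM

Compound 3 gives the lowest of the two numbers in this set of three ureas sharing one core. The nearest number belongs to compound 1, and the gap between them is a 2.9-fold lower number from compound 1 to compound 3 (0.46 log units; beyond the scatter), a modest but real difference. Compound 2 sits at the limit of > 10000 nM in this assay, at which 1 of the 3 values shown sits, so only a limit is known for it. The other two steps, an at least 4.8-fold higher number from compound 1 to compound 2 (0.68 log units; beyond the scatter) and an at least 13-fold lower number from compound 2 to compound 3 (1.14 log units; beyond the scatter), both change chlorine substitution on the aromatic ring attached to the urea nitrogen, and they show that where the chlorines sit on that ring matters a great deal in this assay.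

Compound 4, `O=C(Nc1ccc(OCc2nc3ccccc3s2)cc1)Nc1cc(Cl)cc(Cl)c1`, differs from compound 3 by hydrogen in place of methyl on an aromatic carbon. Going by the values given here, none of the measured steps touches this methyl group; all of them concern the chlorinated ring on the other side of the urea. Among the compounds with values here, there is thus no measured step that bears directly on this change, and the expectation is a step no larger than the usual scatter, in either direction. Compound 4 is therefore estimated at 900 nM, with a range from 300 nM to 2700 nM. This estimate amounts to an expected step of a 1.3-fold higher number from compound 3 to compound 4 (0.10 log units; within the scatter).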

Compound 4, half-maximal inhibitory concentration: 90 nM
For compound 4 the middle estimate is 10-fold (1.00 log units) above the measured one; the measured number lies below the stated range.
By their numbers in this assay, from the lowest: compound 4; then compound 3; then compound 1. At a limit, above all of these: compound 2.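

Every earlier step changed the chlorines on the ring attached to the urea nitrogen, whereas the change on this aromatic carbon in this assay gives an 8.0-fold lower number from compound 3 to compound 4 (0.90 log units; beyond the scatter). Losing a single methyl carbon at a spot that is ortho to a large group and meta to a large group therefore matters here, and the methyl is not needed for inhibition in this pair; the step is larger than the one from adding the two chlorines, which is a 2.9-fold lower number from compound 1 to compound 3 (0.46 log units; beyond the scatter). No measurement shown gives a reason for this step.

The compounds shown leave open whether hydrogen in place of methyl would give a step of similar size on the plain phenyl urea of compound 1 or on the 4-chlorophenyl urea of compound 2, as only the 3,5-dichlorophenyl pair can be read. They also leave open how a fluorine, a methoxy group, an amine or a longer chain such as ethyl on this same carbon would compare with hydrogen and methyl.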